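Amide aryl variation on the enone-linked anilide series

The compounds below may be only part of what the source reports. "The series", "measured", "known", "first", "only" and "open" are said of these compounds alone.

Measured so far in a functional assay on MDA-MB-231 cells (Homo sapiens) for antiproliferative activity, read by CCK-8 assay, with a stated time of 72 h; a lower number here means a stronger inhibitor, a higher number a weaker inhibitor:
compound 1 `Cc1nc(C)c(/C=C/C(=O)c2ccc(NC(=O)c3ccccc3F)cc2)nc1C` gives 1980 nM
compound 2 `COc1ccc(C(=O)Nc2ccc(C(=O)/C=C/c3nc(C)c(C)nc3C)cc2)cc1OC` gives 3360 nM
compound 3 `COc1cccc(OC)c1C(=O)Nc1ccc(C(=O)/C=C/c2nc(C)c(C)nc2C)cc1` gives 3850 nM

Compound 3 holds the largest of the three numbers in this assay, but the steps of a 1.1-fold higher number from compound 2 to compound 3 (0.06 log units; within the scatter) and a 1.9-fold higher number from compound 1 to compound 3 (0.29 log units; within the scatter) both fall within the scatter, so the three measured compounds are not separated from one another. The same holds for a 1.7-fold higher number from compound 1 to compound 2 (0.23 log units; within the scatter).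

Compound 4 `Cc1nc(C)c(/C=C/C(=O)c2ccc(NC(=O)c3ccc(F)cc3)cc2)nc1C` is not yet measured. It differs from compound 3 in one place: 4-fluorophenyl in place of 2,6-dimethoxyphenyl on a carbonyl carbon. Within the data shown here, the step bearing most directly on this change is the one from compound 1 to compound 3, where a fluorophenyl and a dimethoxyphenyl on the same carbonyl carbon gave a 1.9-fold higher number from compound 1 to compound 3 (0.29 log units; within the scatter), within the scatter; the two dimethoxy variants likewise gave a 1.1-fold higher number from compound 2 to compound 3 (0.06 log units; within the scatter). No change of the aryl on this carbonyl has yet moved this assay beyond the scatter, so for compound 4 no step beyond the scatter is expected, with the number expected to sit among the measured values, most likely a little lower, as a 1.5-fold lower number from compound 3 to compound 4 (0.19 log units; within the scatter) from compound 3.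

Compound 4 is estimated at 2500 nM in this assay, with a range from 1000 nM to 6000 nM.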

Compound 4, half-maximal inhibitory concentration: 1670 nM
Compound 4: middle estimate off by 1.5-fold (0.18 log units), on the high side; low and high end bracket the measured number.
By their numbers in this assay, from the lowest: compounds 4, 1, 2 and 3 (each within the scatter of the next, the first and the last beyond it).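

In this assay, among these compounds, the swap of 2,6-dimethoxyphenyl for 4-fluorophenyl gives a 2.3-fold lower number from compound 3 to compound 4 (0.36 log units; beyond the scatter) as the first aryl change on this carbonyl carbon to pass beyond the scatter, so this position does separate at least one pair of groups, though only modestly. Against that, a 2.0-fold lower number from compound 2 to compound 4 (0.30 log units; within the scatter) and a 1.2-fold lower number from compound 1 to compound 4 (0.07 log units; within the scatter) both stay within the scatter, leaving 4-fluorophenyl unseparated from both 3,4-dimethoxyphenyl and 2-fluorophenyl. Compound 1 also remains within the scatter of compound 3, so the series does not divide cleanly into fluorophenyl and dimethoxyphenyl groups.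

Among the compounds shown here, nothing available explains the single separated pair. Still open, from the compounds shown here alone, is whether an aliphatic amine or a carboxylic acid on the aryl ring would move the number further than any aryl change seen so far.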